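The source may hold more compounds than are shown below. What is called first, only, known or untested is meant among the compounds shown, and "the series" means these compounds.

Working notes on the arylpiperazine amides.

Compound 1 `COc1ccccc1N1CCN(CCCCC(=O)NCc2ccccc2-c2cccc(F)c2)CC1` sets the reference point for the pair measured so far. In an assay on CHO-K1 cells for displacement of a labelled ligand from 5-hydroxytryptamine receptor 7 (Homo sapiens), read by scintillation counting (a lower number here means a stronger inhibitor, a higher number a weaker inhibitor), compound 1 gives 34.7 nM, the lowest of the two numbers available. Within the data shown here, the only other measured member, compound 2 `COc1ccccc1N1CCN(CCC(=O)NCc2ccccc2-c2ccccc2)CC1`, differs from compound 1 both in the length of the chain between the piperazine nitrogen and the carbonyl and in the absence of the fluoro; in this assay compound 2 gives 187 nM, which stands beyond the scatter from compound 1. Among the measured compounds shown here, no single-change step between measured compounds is available, so the two values of compound 1 and compound 2 show only that the combined change costs potency.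

Compound 3 `COc1ccccc1N1CCN(CCCCC(=O)NCc2ccccc2-c2ccccc2)CC1` is the next point: it keeps the chain of compound 1 and changes only the terminal ring, (hydrogen in place of fluoro on an aromatic carbon). For the measured compounds named here, with no measured step of this type, the expected step from compound 1 to compound 3, a 1.4-fold higher number from compound 1 to compound 3 (0.16 log units; within the scatter), is held close to the scatter, leaning toward a slightly higher number. Compound 3 is accordingly estimated at 50 nM in this assay, within a range of 20 nM to 130 nM.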

Compound 3, inhibition constant: 37.9 nM
Compound 3: the middle estimate sits 1.3-fold (0.12 log units) above what was measured; measured number inside the range.
By their numbers in this assay, from the lowest: compounds 1 and 3 (each within the scatter of the next); then compound 2.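

In this assay, among these compounds, the change from 3-fluorophenyl to phenyl gives a 1.1-fold higher number from compound 1 to compound 3 (0.04 log units; within the scatter) and is the first single-place step, so with the chain of compound 1 held fixed, the fluoro at this place on the terminal ring has no effect that can be read against the hydrogen. Compound 3 and compound 2 differ only in the chain, and their printed values, compound 3 at 37.9 nM and compound 2 at 187 nM, suggest that the gap seen earlier for the combined change goes with the chain rather than the fluoro, at least across these three compounds. No measurement at hand offers an explanation for the level result at the fluoro position.

As far as these compounds go, it remains open whether a chloro, a methoxy or a trifluoromethyl at this same place would also leave the number level, and whether a fluoro on the shorter chain of compound 2 would behave as it does on the chain of compound 1. From the compounds shown here alone, how a chain longer than that of compound 1 would read in this assay also remains open.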